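Moving the ring hydroxyl: clearance of a positional isomer

This account rests on a few compounds, and the source may have more. Where it says the series, first, only, none or still open, it means among the compounds named here.

Compound 2 `Cn1nc(-c2ccc(C(N)=O)cc2)s/c1=N\C1CCC(O)CC1` is the reference here. Within the data shown here, in an in vivo ADME assay on the whole organism for pharmacokinetics, at a dose of 0.5 mg/kg by the intravenous route (a higher number here means faster removal of the compound, a lower number slower removal), compound 2 gives 66.9 mL/min/kg, the only number recorded for it, with one further entry that gave no single number. Its companion compound 1 `Cn1nc(-c2ccc(C(N)=O)cc2)s/c1=N\C1CCCC(O)C1` was measured more than once in this assay, where compound 1 gives 34.4 mL/min/kg; 59.9 mL/min/kg (2 entries); the spread across those entries, (the several entries of compound 1 in this assay, 34.4 mL/min/kg; 59.9 mL/min/kg (2 entries)), shows how much repeated measurement of the same compound can move. Among the measured compounds shown here, no step between measured compounds is recorded, so nothing is known yet about how position of the hydroxyl affects clearance.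

Compound 3 `Cn1nc(-c2ccc(C(N)=O)cc2)s/c1=N\C1CCCCC1O` is not yet measured. It differs from compound 2 in one place: 2-hydroxycyclohexyl in place of 4-hydroxycyclohexyl on a double-bonded nitrogen. Since the two are made of the same atoms joined differently, the expected step of a 1.2-fold lower number from compound 2 to compound 3 (0.09 log units; within the scatter) is none beyond the scatter. Compound 3 is accordingly estimated at 55 mL/min/kg, with a range from 28 mL/min/kg to 100 mL/min/kg.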

Compound 3, clearance: 38.2 mL/min/kg
Compound 3: the middle estimate sits 1.4-fold (0.16 log units) above what was measured; low and high end bracket the measured number.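

In this assay, among these compounds, the one direct comparison at this position is a 1.8-fold lower number from compound 2 to compound 3 (0.24 log units; within the scatter), so moving the hydroxyl from 4-hydroxycyclohexyl to 2-hydroxycyclohexyl on the double-bonded nitrogen gives no change that can be told apart from repeat measurement. Repeated entries of a single compound spread about as widely: the several entries of compound 1 in this assay, 34.4 mL/min/kg; 59.9 mL/min/kg (2 entries)

Compound 2 and compound 3 therefore cannot be ranked on clearance, although a real difference of this size is not excluded either. As far as these compounds go, what remains open is whether replacing the hydroxyl with another group, such as an amine or a carboxylic acid, would give a step beyond the scatter. From the compounds shown here alone, it is also open whether a change elsewhere on the shared core would matter more than the place of the hydroxyl on the cyclohexyl ring.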